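Demethylation of the amine tail and Vero cell tolerance

This account rests on a few compounds, and the source may have more. Where it says the series, first, only, none or still open, it means among the compounds named here.

Compound 1, `CC(CN(C)C)NC(=O)c1cc(C2CC2)nc2c1cnn2C(C)C`, gives > 300000 nM in an ADME assay on Vero cells (Chlorocebus sabaeus) for cytotoxicity, read by neutral red uptake, with a stated time of 3 days; a lower number here means that less compound is tolerated, a higher number that more compound is tolerated. Compound 2, `CC(CN)NC(=O)c1cc(C2CC2)nc2c1cnn2C(C)C`, gives 164000 nM. Compound 3, `CC(C)n1ncc2c(C(=O)NCCN(C)C)cc(C(C)(C)C)nc21`, gives 34400 nM.

The value of compound 1 is a limit of this assay, not a number (the limit of > 300000 nM in this assay, at which 1 of the 3 values shown sits). The change amino in place of dimethylamino on a saturated chain carbon, two bonds along the chain from an amide-type nitrogen gave a step of an at least 1.8-fold lower number from compound 1 to compound 2 (0.26 log units; that floor lies within the scatter). Compound 3 has the lowest of the two numbers; the difference between its core and that of compound 1 is not broken down here. Compound 4, `CC(C)n1ncc2c(C(=O)NCCN)cc(C(C)(C)C)nc21`, carries the same change, (amino in place of dimethylamino on a saturated chain carbon, two bonds along the chain from an amide-type nitrogen), made on the core of compound 3. The expected step is a 1.3-fold lower number from compound 3 to compound 4 (0.12 log units; within the scatter), resting on an at least 1.8-fold lower number from compound 1 to compound 2 (0.26 log units; that floor lies within the scatter). Compound 4 is therefore estimated at 26000 nM, between 10000 nM and 80000 nM.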

Compound 4, half-maximal cytotoxic concentration: 23000 nM
The estimate for compound 4 lay 1.1-fold (0.05 log units) above the measured number, and the stated range covers the measured number.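

In this assay the same change on the core of compound 3 gave a 1.5-fold lower number from compound 3 to compound 4 (0.17 log units; within the scatter) and so, on this core, the amino and dimethylamino tails cannot be told apart. The two cores give no sign that the change carries differently from one to the other, but they do not establish that it carries unchanged: the same change on two cores in this assay, an at least 1.8-fold lower number (0.26 log units; that floor lies within the scatter) from compound 1 to compound 2 and a 1.5-fold lower number (0.17 log units; within the scatter) from compound 3 to compound 4; the limit leaves it open whether they differ. For compound 1 the reading is a limit and not a number: > 300000 nM.

The compounds shown leave open how a methylamino tail, or a longer chain between the amide nitrogen and the amine, would read in this assay. They also leave open whether the change behaves alike on any third core.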